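The compounds below may be only part of what the source reports. "The series", "measured", "known", "first", "only" and "open" are said of these compounds alone.

Two compounds of the series carry numbers in a toxicity assay on HUVEC cells (Homo sapiens) for inhibition; a lower number here means a stronger inhibitor of growth, a higher number a weaker inhibitor of growth. Compound 1 `Cc1nc(-c2ccccc2)c(C(=O)N2CCN(c3ccc(C)c(C)c3)CC2)o1` gives 3.52 ug/mL in this assay, the highest of the two values. Compound 2 `COc1cc(OC)cc(N2CCN(C(=O)c3oc(C)nc3-c3ccccc3F)CC2)c1` gives 0.118 ug/mL in this assay, a lower number than compound 1 by a margin beyond the usual scatter; compound 2 differs from compound 1 in more than one place, so the two values alone do not tell which change carries that gap.

Compound 3 `Cc1ccc(C)c(N2CCN(C(=O)c3oc(C)nc3-c3ccccc3)CC2)c1` has not yet been measured in this assay. It has the same atoms as compound 1, joined differently: 2,5-dimethylphenyl in place of 3,4-dimethylphenyl on an amine nitrogen in a ring. Among the compounds with values here, no measured pair isolates an exchange of one dimethylphenyl group for another, so nothing measured sets the size of this step. Compound 3 is expected to show only a small step, a 1.1-fold lower number from compound 1 to compound 3 (0.04 log units; within the scatter), likely within the scatter and without a clear direction. Compound 3 is accordingly estimated at 3.2 ug/mL in this assay, within a range of 1 ug/mL to 10 ug/mL.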

Compound 3, concentration for 50% growth inhibition: 1.73 ug/mL
Compound 3: middle estimate off by 1.8-fold (0.27 log units), on the high side, within the range that was stated.
By their numbers in this assay, from the lowest: compound 2; then compound 3; then compound 1.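

In this assay, within the data shown here, the exchange of 3,4-dimethylphenyl for 2,5-dimethylphenyl on the amine nitrogen in the ring gives a 2.0-fold lower number from compound 1 to compound 3 (0.31 log units; beyond the scatter) and is the first step that isolates a single place. Compound 1 and compound 3 have the same atoms and the exchanged groups match in every count computed for them. This step shows that the arrangement of the two methyl groups alone can shift the number by a modest margin beyond the usual scatter, while the rest of the molecule stays the same. Nothing available bears on why this arrangement gives the lower number, so the step stands as an observation without an explanation.

A single pair cannot show whether the step would hold with the other parts of the molecule changed, and compound 2 differs from both compound 1 and compound 3 in more than one place, so the compounds shown do not separate its aryl group from its fluorine-bearing phenyl group. Also open, on these data alone, is how a chlorophenyl or a pyridine ring on the same amine nitrogen would compare with the two dimethylphenyl groups.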